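This account rests on a few compounds, and the source may have more. Where it says the series, first, only, none or still open, it means among the compounds named here.

Measured compounds:
- compound 1, `COc1cc2c(cc1N1C[C@@H](C)N(C)[C@@H](C)C1)N(C(=O)c1ccc(-c3ccccc3C)cc1)CC2` — 0.631 nM
- compound 2, `COc1cc2c(cc1N1C[C@@H](C)N[C@@H](C)C1)N(C(=O)c1ccc(-c3cc(C)ncc3C)cc1)CC2` — 7.94 nM

In an assay on isolated protein for binding affinity to 5-hydroxytryptamine receptor 1B (Homo sapiens) (on this read-out lower numbers stand for stronger inhibition and higher numbers for weaker inhibition), compound 1 gives the lowest of the two numbers shown. Compound 2 sits well above it, beyond the usual scatter, but the two compounds differ in more than one place, so no single step can be read from that pair.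

Compound 3, `COc1cc2c(cc1N1C[C@@H](C)N(C)[C@@H](C)C1)N(C(=O)c1ccc(-c3ccc(-c4noc(C)n4)cc3C)cc1)CC2`, is compound 1 with one change: 5-methyl-1,2,4-oxadiazol-3-yl in place of hydrogen on an aromatic carbon. For the measured compounds named here, no pair already measured shows a change of this kind, so nothing in the set tells how large a step to expect. The terminal aryl ring of compound 1 already carries a methyl group, and the change adds a heteroaromatic ring on that same ring. The expectation is a step of modest size, a 1.6-fold higher number from compound 1 to compound 3 (0.20 log units; within the scatter), likely within the scatter. Compound 3 is therefore estimated at 1 nM, with a range from 0.3 nM to 3.2 nM.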

Compound 3, inhibition constant: 5.01 nM
Compound 3: middle estimate off by 5.0-fold (0.70 log units), on the low side; measured number outside the range, above it.
By their numbers in this assay, from the lowest: compound 1; then compounds 3 and 2 (each within the scatter of the next).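

In this assay, 5-methyl-1,2,4-oxadiazol-3-yl on the aromatic carbon para to a large group and meta to a methyl group gives a 7.9-fold higher number from compound 1 to compound 3 (0.90 log units; beyond the scatter) and so costs affinity beyond the scatter. For the compounds shown here, this is the first reading at this position: it accepts the added heteroaromatic ring, with compound 3 still at 5.01 nM, but not without loss against the unsubstituted carbon of compound 1. Going by these compounds alone, nothing measured so far accounts for the size of this step.

From the compounds shown here alone, whether the loss belongs to this particular ring or to any substituent at this carbon stays open, and a methoxy group or a carboxylic acid at the same place would help separate the two readings. Steps to compound 2 cannot be read, since it differs from the other compounds in more than one place.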